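Swapping the hydroxyphenyl ring in compound 1: an expectation

This account rests on a few compounds, and the source may have more. Where it says the series, first, only, none or still open, it means among the compounds named here.

Measured compounds:
Compound 1, `COc1cc(CNC(=O)/C=C/c2ccc(O)cc2)ccc1OCc1nc(C)c(C)nc1C`, in a functional assay on SH-SY5Y cells (Homo sapiens) for cytotoxicity, read by MTT assay, with stated times of 24 h and 4 h (on this read-out lower numbers stand for an effect already at smaller amounts and higher numbers for an effect only at larger amounts of compound), compound 1 gives 3740 nM.
Compound 2, `COc1cc(CNC(=O)/C=C/c2ccc(OCc3nc(C)c(C)nc3C)cc2)ccc1OCc1nc(C)c(C)nc1C`, in this assay compound 2 gives 7770 nM.
Compound 3, `COc1ccc(/C=C/C(=O)NCc2ccc(O)c(OC)c2)cc1`, in this assay compound 3 gives 11400 nM.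

Among these three, compound 1 holds the lowest number; compound 2 sits nearest to it and compound 3 furthest, both beyond the scatter. Compound 4, `COc1cc(CNC(=O)/C=C/c2cccc(OC)c2OC)ccc1OCc1nc(C)c(C)nc1C`, has not been measured. It differs from compound 1 in one place: 2,3-dimethoxyphenyl in place of 4-hydroxyphenyl on a double-bonded chain carbon bound to a double-bonded chain carbon. The ring that leaves carries the only hydrogen-bond donor of that part; the ring that enters carries none.

For the measured compounds named here, one measured step bears on this: a 2.1-fold higher number from compound 1 to compound 2 (0.32 log units; beyond the scatter). There, too, the hydroxyl hydrogen was lost, and the number rose modestly. Compound 3, which carries a methoxy group where compound 1 carries a hydroxyl, shows a still higher number than compound 1, although the two also differ elsewhere, so this pair gives only a hint in the same direction.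

For compound 4 a modest rise is therefore expected, a 2.0-fold higher number from compound 1 to compound 4 (0.30 log units; within the scatter). The estimate for compound 4 is 7500 nM, with a likely range from 3500 nM to 16000 nM.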

Compound 4, half-maximal effective concentration: 7150 nM
Estimate against measurement, compound 4: 1.0-fold (0.02 log units) above; the measured number falls inside the stated range.
By their numbers in this assay, from the lowest: compounds 1, 4, 2 and 3 (each within the scatter of the next, the first and the last beyond it).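

In this assay, putting 2,3-dimethoxyphenyl in place of 4-hydroxyphenyl on a double-bonded chain carbon bound to a double-bonded chain carbon gives a 1.9-fold higher number from compound 1 to compound 4 (0.28 log units; within the scatter), so this read-out does not separate compound 1 from compound 4. This is new information about the position: the entering group has more heavy atoms than the leaving one and no hydrogen-bond donor, yet the step stays within the scatter, whereas the earlier step at this part of the molecule, a 2.1-fold higher number from compound 1 to compound 2 (0.32 log units; beyond the scatter), lay just beyond it. No measurement shown here accounts for this outcome or says what happens inside the cells at this position.

Because the hydroxyl leaves and two methoxy groups enter in one change, this single step cannot show what each of those alterations contributes on its own. From the compounds shown here alone, it also remains open whether the number in this assay would stay in the same region with a quite different group on this ring, such as an amine or a carboxylic acid.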